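This account rests on a few compounds, and the source may have more. Where it says the series, first, only, none or still open, it means among the compounds named here.

Three compounds built on the shared core of compound 1 `CC(=O)Nc1ccc(S(=O)(=O)Oc2ccccc2C(C)C)cc1` have been measured in a functional assay on HT-29 cells (Homo sapiens) for antiproliferative activity, read by sulforhodamine B assay, with a stated time of 48 h; a lower number here means a stronger inhibitor, a higher number a weaker inhibitor. Compound 1 gives 23000 nM. Compound 2 `CCC(=O)Nc1ccc(S(=O)(=O)Oc2ccccc2C(C)C)cc1` gives 7400 nM, and compound 3 `CCCNC(=O)Nc1ccc(S(=O)(=O)Oc2ccccc2C(C)C)cc1` gives 6300 nM. Compound 3 and compound 2 lie within the scatter of each other, as the step shows: a 1.2-fold lower number from compound 2 to compound 3 (0.07 log units; within the scatter). Both stand clearly apart from compound 1, with a 3.7-fold lower number from compound 1 to compound 3 (0.56 log units; beyond the scatter) and a 3.1-fold lower number from compound 1 to compound 2 (0.49 log units; beyond the scatter).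

Compound 4 `CC(C)c1ccccc1OS(=O)(=O)c1ccc(NC(=O)NCCCCl)cc1` differs from compound 3 by one change: chloro in place of hydrogen on a saturated chain carbon, three bonds along the chain from an amide-type nitrogen. Within the data shown here, none of the measured steps touches this part of the molecule. All three concern the group bound to the carbonyl carbon, so they give no direct guide to the new chloro. The two steps that go beyond the scatter both come from exchanging a small group on the carbonyl carbon for a larger one, while the exchange of ethyl for propylamino stays within the scatter. With nothing measured that speaks to the new position, the expectation for this assay is a step of no more than the scatter in either direction, a 1.1-fold lower number from compound 3 to compound 4 (0.02 log units; within the scatter). Compound 4 is therefore estimated at 6000 nM, with a likely range from 2500 nM to 15000 nM.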

Compound 4, half-maximal inhibitory concentration: 6900 nM
Compound 4: the middle estimate sits 1.2-fold (0.06 log units) below what was measured; low and high end bracket the measured number.
By their numbers in this assay, from the lowest: compounds 3, 4 and 2 (each within the scatter of the next); then compound 1.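

In this assay, chloro on a saturated chain carbon, three bonds along the chain from an amide-type nitrogen, is the first change shown at this position, and turning propyl into 3-chloropropyl stays within the scatter (a 1.1-fold higher number from compound 3 to compound 4 (0.04 log units; within the scatter)). The longer group also stays within the scatter of the ethyl compound (a 1.1-fold lower number from compound 2 to compound 4 (0.03 log units; within the scatter)), and the distance from the methyl compound remains beyond the scatter (a 3.3-fold lower number from compound 1 to compound 4 (0.52 log units; beyond the scatter)), so adding this one chlorine atom leaves the standing of the series in this assay unchanged. No supporting measurement is available to explain why this change has so small an effect.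

A single substitution cannot show whether this chain position is insensitive to change in general or whether chloro is simply one group that fits the pattern, so a hydroxyl group, an amine, a carboxylic acid or a longer chain carrying the same chlorine could behave differently. Also open, on these data alone, is whether chloro would leave the number just as little changed on a chain carbon closer to the amide-type nitrogen.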